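Cyclohexyl to 2-methylphenyl on the amine side chain

The source may hold more compounds than are shown below. What is called first, only, known or untested is meant among the compounds shown, and "the series" means these compounds.

Compound 1 `CC1(C)CCCN(CC2(O)CCN(CCCc3c[nH]c4ccc(-n5cnnc5)cc34)CC2)C1`: 0.9 nM
Compound 2 `CN(CC1CCCCC1)CC1(O)CCN(CCCc2c[nH]c3ccc(-n4cnnc4)cc23)CC1`: 1.4 nM

Both compounds were tested in a functional assay on CHO cells for agonist activity at 5-hydroxytryptamine receptor 1D (Homo sapiens), read by GTPgammaS binding; a lower number here means that less compound is needed, a higher number that more compound is needed for the effect. For the measured compounds named here, compound 2 has the higher of the two numbers, but the only measured step, a 1.6-fold higher number from compound 1 to compound 2 (0.19 log units; within the scatter), lies within the scatter, so the two are not told apart. That step exchanged one amine substituent pattern for another while keeping a saturated ring.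

Compound 3 `Cc1ccccc1CN(C)CC1(O)CCN(CCCc2c[nH]c3ccc(-n4cnnc4)cc23)CC1` differs from compound 2 in one place: 2-methylphenyl in place of cyclohexyl on a saturated chain carbon bound to an amine nitrogen. Going by the values given here, no measured step exchanges a saturated ring for an aromatic ring, so the nearest guide is the single step of a 1.6-fold higher number from compound 1 to compound 2 (0.19 log units; within the scatter), which was small. On that basis the expected step of a 1.4-fold higher number from compound 2 to compound 3 (0.15 log units; within the scatter) is none beyond the scatter, with a wide range to allow for the untested ring change. Compound 3 is therefore estimated at 2 nM, between 0.6 nM and 7 nM.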

Compound 3, concentration for half-maximal effect: 3.7 nM
Compound 3: the middle estimate sits 1.9-fold (0.27 log units) below what was measured, and the stated range covers the measured number.
By their numbers in this assay, from the lowest: compounds 1 and 2 (each within the scatter of the next); then compound 3.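

In this assay, 2-methylphenyl in place of cyclohexyl on a saturated chain carbon bound to an amine nitrogen gives a 2.6-fold higher number from compound 2 to compound 3 (0.42 log units; beyond the scatter). For the compounds shown here, this is the first step to pass beyond the scatter, so this place does respond to exchanging a non-aromatic ring for an aromatic one, though only modestly. The wider comparison, a 4.1-fold higher number from compound 1 to compound 3 (0.61 log units; beyond the scatter), with methyl(2-methylbenzyl)amino in place of 3,3-dimethylpiperidin-1-yl, is also modest, and no measurement in hand explains either step.

The change brings in an aromatic ring and a methyl group together, so the compounds shown do not separate the two, which unsubstituted phenyl could do. As far as these compounds go, how a pyridine ring or a methoxy-bearing phenyl would read at this place also stays open.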